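The source may report more compounds than this note shows. Statements on the series, on what has been measured and on what is new or still open speak of the compounds shown alone.

Measured compounds:
compound 1, `Cc1noc(C)c1-c1cnc(N)c(Oc2ccc(C(=O)NC3CCCC3)cc2)n1`, 57600 nM
compound 2, `Cc1noc(C)c1-c1cnc(N)c(Oc2ccc(C(=O)Nc3ccccc3)cc2)n1`, 26600 nM

The numbers come from a functional assay on U-87MG ATCC cells for inhibition, with U-87 MG (Homo sapiens) as the target, read by MTT assay, with a stated time of 72 h; a higher number here means a weaker inhibitor, a lower number a stronger inhibitor. Compound 1 has the highest of the two numbers; its nearest neighbour is compound 2, and the step of a 2.2-fold lower number from compound 1 to compound 2 (0.34 log units; beyond the scatter) is beyond the scatter, though modest. Compound 3, `Cc1noc(C)c1-c1cnc(N)c(Oc2ccc(C(=O)Nc3ccc(Cl)cn3)cc2)n1`, has not been measured. It differs from compound 1 in one place: 5-chloropyridin-2-yl in place of cyclopentyl on an amide-type nitrogen. Among the measured compounds shown here, the only measured step that bears on this change is the one from compound 1 to compound 2, where an aromatic ring replaced the same cyclopentyl on the same amide-type nitrogen. Compound 3 also carries an aromatic ring there, so a step of comparable size and in the same direction is expected, giving a lower number in this assay. The step from compound 1 to compound 3 is estimated at a 2.9-fold lower number from compound 1 to compound 3 (0.46 log units; beyond the scatter). For compound 3 the expected value is 20000 nM, with a range from 8000 nM to 50000 nM.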

Compound 3, half-maximal inhibitory concentration: 45600 nM
Beside the measured number, compound 3's estimate is 2.3-fold (0.36 log units) below it; measured number inside the range.
By their numbers in this assay, from the lowest: compounds 2, 3 and 1 (each within the scatter of the next, the first and the last beyond it).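

In this assay, the phenyl result does not extend to every aromatic ring on the amide-type nitrogen: 5-chloropyridin-2-yl in place of cyclopentyl gives a 1.3-fold lower number from compound 1 to compound 3 (0.10 log units; within the scatter), and 5-chloropyridin-2-yl in place of phenyl gives a 1.7-fold higher number from compound 2 to compound 3 (0.23 log units; within the scatter). Both steps lie within the scatter, so compound 3 cannot be separated from either compound 1 or compound 2, even though those two stand apart, and this position shows only a narrow spread across the three groups. Nothing shown explains this outcome.

The compounds shown leave open whether the chlorine, the ring nitrogen or neither sets the reading of 5-chloropyridin-2-yl. They also leave open how an unsubstituted pyridin-2-yl, a chlorophenyl or a benzyl group would read on the same amide-type nitrogen.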